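This account rests on a few compounds, and the source may have more. Where it says the series, first, only, none or still open, it means among the compounds named here.

In a functional assay for inhibition, with Homo sapiens as the target (on this read-out lower numbers stand for tighter binding and higher numbers for weaker binding), compound 1 `CC(C)(Oc1ccccc1O)C1OCC(C/C=C\CCC(=O)O)C(c2cccnc2)O1` gives 95.5 nM, while compound 2 `CC(C)(Sc1ccccc1)C1OCC(C/C=C\CCC(=O)O)C(c2cccnc2)O1` gives 200 nM. Compound 2 therefore has the higher of the two numbers, which means the weaker binding. The next structure, compound 3 `CC(C)(Cc1ccc(F)cc1)C1OCC(C/C=C\CCC(=O)O)C(c2cccnc2)O1`, keeps the rest of compound 2 and changes one group on a saturated chain carbon bound to two saturated chain carbons and a saturated ring carbon, where 4-fluorobenzyl takes the place of phenylsulfanyl: 4-fluorobenzyl in place of phenylsulfanyl on a saturated chain carbon bound to two saturated chain carbons and a saturated ring carbon. Both groups carry one six-membered aromatic ring of carbon only.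

Within the data shown here, only one measured step bears on this place: a 2.1-fold higher number from compound 1 to compound 2 (0.32 log units; beyond the scatter). That step is modest, so swapping the group here has so far moved the number only a little. Among the measured compounds shown here, it involved a different pair of groups, however, and no measured compound carries 4-fluorobenzyl, so the data give no direction for the new change. The expected result is therefore no step beyond the scatter, and the estimated step is a 1.1-fold lower number from compound 2 to compound 3 (0.05 log units; within the scatter). The estimate for compound 3 is 180 nM, with an expected range from 60 nM to 500 nM.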

Compound 3, dissociation constant: 89.1 nM
The estimate for compound 3 lay 2.0-fold (0.31 log units) above the measured number; the measured number falls inside the stated range.
By their numbers in this assay, from the lowest: compounds 3 and 1 (each within the scatter of the next); then compound 2.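

In this assay, a 2.2-fold lower number from compound 2 to compound 3 (0.35 log units; beyond the scatter) shows that the group on this saturated chain carbon can move the number down as well as up, and that phenylsulfanyl, the group leaving here, gives the weakest binding of the three compounds. The second comparison, a 1.1-fold lower number from compound 1 to compound 3 (0.03 log units; within the scatter), places 4-fluorobenzyl and 2-hydroxyphenoxy level with each other, so a group with 0 hydrogen-bond donors, as counted for 4-fluorobenzyl, does as well here as 2-hydroxyphenoxy with its hydroxyl. Nothing available explains why phenylsulfanyl stands apart from the other two groups.

The compounds shown leave open how much of this result rests on the fluorine, which a plain benzyl group would test, and how much on the atom linking the aromatic ring to the chain carbon, which a plain phenoxy group would test. Going by these compounds, it also remains open whether this position would tolerate something quite different, such as an amine or a longer chain ending in the same aromatic ring.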